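Amino substitution on the shared core, two matched pairs

The source may report more compounds than this note shows. Statements on the series, on what has been measured and on what is new or still open speak of the compounds shown alone.

Measured so far:
- Compound 1 `COc1ncnc2c1c(-c1ccsc1)cn2[C@@H]1O[C@H](CO)[C@@H](O)[C@H]1O`: in a functional assay on K562 cells (Homo sapiens), read by MTT assay, with a stated time of 72 h (a higher number here means a weaker inhibitor, a lower number a stronger inhibitor), compound 1 gives 90 nM.
- Compound 2 `COc1nc(N)nc2c1c(-c1ccsc1)cn2[C@@H]1O[C@H](CO)[C@@H](O)[C@H]1O`: in this assay compound 2 gives > 20000 nM, which is a limit of the assay and not a number.
- Compound 3 `O=c1[nH]cnc2c1c(-c1ccco1)cn2[C@@H]1O[C@H](CO)[C@@H](O)[C@H]1O`: in this assay compound 3 gives 15500 nM.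

Going by the values given here, the one change that is measured here is amino in place of hydrogen on an aromatic carbon. It produces an at least 220-fold higher number from compound 1 to compound 2 (2.34 log units; beyond the scatter). The value of compound 2 sits at the limit of > 20000 nM in this assay, at which 1 of the 3 values shown sits, so only a lower bound on the loss is known.

Compound 3 carries a different core; the difference between the core of compound 3 and the core of compound 1 is not broken down here. Of the two numbers, compound 3 gives 15500 nM and compound 1 gives 90 nM.

Compound 4 `Nc1nc2c(c(-c3ccco3)cn2[C@@H]2O[C@H](CO)[C@@H](O)[C@H]2O)c(=O)[nH]1` is not yet measured. It is reached from compound 3 by amino in place of hydrogen on an aromatic carbon. Among the compounds with values here, this is the same kind of change as the one from compound 1 to compound 2, though the surroundings differ: in compound 1 the new group stands meta to a methoxy group (2 heavy atoms), in compound 3 meta to a group of 1 heavy atom.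

For compound 4 in this assay the expected step is a 3.9-fold higher number from compound 3 to compound 4 (0.59 log units; beyond the scatter), resting on the single measured case an at least 220-fold higher number from compound 1 to compound 2 (2.34 log units; beyond the scatter). Compound 3 already gives 15500 nM, and compound 4 is expected to give a higher number still. The estimate for compound 4 is 60000 nM, expected to lie from 20000 nM to 400000 nM.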

Compound 4, half-maximal inhibitory concentration: > 20000 nM
Compound 4 gave a limit, no number; the forecaster's own chance of this, stated with the estimate: 85%; the middle value is on the limit's open side.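

Amino in place of hydrogen on an aromatic carbon, carried to the core of compound 3, gives an at least 1.2-fold higher number from compound 3 to compound 4 (0.11 log units; that floor lies within the scatter) in this assay, and this is only a floor, as compound 4 stands at a limit and not a number. Set beside the step on the core of compound 1, this result shows neither that the size of the change carries over from one core to the other nor that it fails to: the same change on two cores in this assay, an at least 220-fold higher number (2.34 log units; beyond the scatter) from compound 1 to compound 2 and an at least 1.2-fold higher number (0.11 log units; that floor lies within the scatter) from compound 3 to compound 4; the limit leaves it open whether they differ. What does carry across is limited to direction, as neither step shows a lower number with the amino group, while the true size of both steps remains unread and the ceiling of the assay caps the comparison: the limit of > 20000 nM in this assay, at which 2 of the 4 values shown sit.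

Open, from the compounds shown here alone, is whether a group other than amino on the same carbon, between two ring nitrogen atoms, such as methylamino, dimethylamino, hydroxyl or chlorine, would give numbers below the limit on either core. Also open, going by these compounds, is how much of the gap between compound 1 and compound 3 belongs to the methoxy group and how much to the other differences between these two compounds, which differ in more than one place.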